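The source may hold more compounds than are shown below. What is called first, only, known or untested is meant among the compounds shown, and "the series" means these compounds.

Measured compounds:
compound 1 `Cc1cccc(C#Cc2ccc3c(n2)CCN(C)C3=O)c1` gives 2.9 nM in a functional assay on HEK293 cells for negative allosteric modulation of metabotropic glutamate receptor 5 (Homo sapiens), read by FLIPR and calcium flux; on this read-out lower numbers stand for stronger inhibition and higher numbers for weaker inhibition
compound 2 `Cc1cccc(C#Cc2ccc3c(n2)CCN(C(C)C)C3=O)c1` gives 4.8 nM in this assay

Compound 2 holds the higher of the two numbers in this assay; its nearest neighbour is compound 1, and the step of a 1.7-fold higher number from compound 1 to compound 2 (0.22 log units; within the scatter) lies within the scatter, so the two cannot be ordered. Compound 3 `CC(C)N1CCc2nc(C#Cc3cccs3)ccc2C1=O` is not yet measured. It differs from compound 2 in one place: thiophen-2-yl in place of 3-methylphenyl on a triple-bonded carbon. Among the compounds with values here, the only measured step, from compound 1 to compound 2, concerns the substituent on the amide-type nitrogen in a ring and says nothing about the group on the triple-bonded carbon. The data therefore hold no comparison that bears on this change, and the expectation for compound 3 rests on compound 2 alone, with a wide range. Compound 3 is estimated at 8 nM (range 2 nM to 40 nM), which means an expected step of a 1.7-fold higher number from compound 2 to compound 3 (0.22 log units; within the scatter), not clearly beyond the scatter.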

Compound 3, half-maximal inhibitory concentration: 45 nM
The estimate for compound 3 lay 5.6-fold (0.75 log units) below the measured number; measured number above the stated range.
By their numbers in this assay, from the lowest: compounds 1 and 2 (each within the scatter of the next); then compound 3.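

Within the data shown here, the group on the triple-bonded carbon is the first place where a single change moves the number clearly in this assay: thiophen-2-yl in place of 3-methylphenyl gives a step beyond the scatter (a 9.4-fold higher number from compound 2 to compound 3 (0.97 log units; beyond the scatter)). The earlier change, isopropyl in place of methyl on the amide-type nitrogen, stayed within the scatter (a 1.7-fold higher number from compound 1 to compound 2 (0.22 log units; within the scatter)), so the series now shows a position where the group matters, with 3-methylphenyl clearly ahead of thiophen-2-yl on this core. Nothing in the data shown accounts for this step.

The compounds shown leave open whether thiophen-2-yl gives a similar step with methyl on the nitrogen, as in compound 1. Going by these compounds, it is also open whether an unsubstituted phenyl, a pyridyl or a 3-chlorophenyl on the triple-bonded carbon would stand near compound 2 or near compound 3.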